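Compound 1 Loses Its Cyclohexyl Group

A few compounds are considered here, and "the series" means these few. Any claim that something is new, unique, unknown or untested is made for them only; others in the source may bear on it.

Among the compounds with values here, in an in vitro ADME assay on the whole organism (small intestine) for pharmacokinetics, with Rattus norvegicus as the target (a lower number here means that the compound disappears faster, a higher number that the compound lasts longer), compound 1 `C/C(=C\c1ccc(C(=O)Oc2ccc(C(=N)N)cc2)cc1)C(=O)N(CC(=O)O)C1CCCCC1` gives 0.817 h, the only actual number so far. Compound 2 `CCOC(=O)CN(C(=O)/C(C)=C/c1ccc(C(=O)Oc2ccc(C(=N)N)cc2)cc1)C1CCCCC1` gives > 1 h, which is a limit of the assay and not a number. Within the data shown here, the single measured step, an at least 1.2-fold higher number from compound 1 to compound 2 (0.08 log units; that floor lies within the scatter), lies within the scatter and puts ethyl in place of hydrogen on an oxygen. Compound 3 `C=CCN(CCC(=O)O)C(=O)/C(C)=C/c1ccc(C(=O)Oc2ccc(C(=N)N)cc2)cc1` carries a different change: allyl(2-carboxyethyl)amino in place of (carboxymethyl)(cyclohexyl)amino on a carbonyl carbon. Among the measured compounds shown here, no measured step makes this exchange, and the one available step gives no size to carry over. The expectation therefore stays anchored on compound 1 at 0.817 h, with no direction favoured in this assay. The expected step, a 1.0-fold lower number from compound 1 to compound 3 (0.01 log units; within the scatter), is estimated to stay within the scatter. For compound 3 the estimated half-life is 0.8 h, with an expected range of 0.4 h to 1.6 h.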

Compound 3, half-life: > 1 h
Compound 3: a limit, no number; the forecaster's own chance of this, stated with the estimate: 30%; middle value at least 1.2-fold (0.09 log units) away from the limit.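

In this assay, allyl(2-carboxyethyl)amino in place of (carboxymethyl)(cyclohexyl)amino on a carbonyl carbon gives an at least 1.2-fold higher number from compound 1 to compound 3 (0.08 log units; that floor lies within the scatter). Compound 3 gives > 1 h, which is a limit of the assay and not a number. The earlier step changed only a hydrogen on an oxygen, whereas this one shows that the six-membered ring can leave this place, with a carboxy group still present, and the reading still reaches that limit.

Going by these compounds, how far either exchange really moves the half-life stays open, since only a floor can be read for both steps and the limit caps what the values can show: the limit of > 1 h in this assay, at which 2 of the 3 values shown sit. On these data alone, it is also open how an amine in place of the carboxylic acid, or a longer chain, would read at this place.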